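The source may hold more compounds than are shown below. What is called first, only, known or untested is meant among the compounds shown, and "the series" means these compounds.

Compound 1, `O=C1c2ccccc2NS(=O)(=O)N1Cc1ccccc1`, gives 50 ug/mL in a functional assay on HEL cells (Homo sapiens) for cytotoxicity; a lower number here means that less compound is tolerated, a higher number that more compound is tolerated. Compound 2, `O=C1c2ccccc2N(COCCO)S(=O)(=O)N1Cc1ccccc1`, reaches only the limit of the assay, > 50 ug/mL, which is not a number.

Compound 1 thus stands as the only number shown in this assay; the one further value shown is a limit. The step of a number no lower from compound 1 to compound 2 (the limit leaves the size open) replaces a hydrogen with (2-hydroxyethoxy)methyl on a sulfonamide nitrogen in a ring, and its size cannot be read because of the limit of > 50 ug/mL in this assay, at which 1 of the 2 values shown sits.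

Compound 3, `C#CCOCN1C(=O)c2ccccc2NS1(=O)=O`, differs from compound 1 by propargyloxy in place of phenyl on a saturated chain carbon bound to an amide-type nitrogen in a ring. No measured step touches that same place, so no measured step bears directly on this change, and the one step shown gives no readable size. The step of no change at the digits printed from compound 1 to compound 3 (within the scatter) is therefore expected to be none beyond the scatter. Compound 3 is expected to give 50 ug/mL in this assay, within a range from 25 ug/mL to 100 ug/mL.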

Compound 3, minimum cytotoxic concentration: > 50 ug/mL
Compound 3: no number, only a limit; the forecaster's own chance of this, stated with the estimate: 40%; the middle value sits exactly at the limit.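

In this assay, putting propargyloxy in place of phenyl gives a number no lower from compound 1 to compound 3 (the limit leaves the size open). Until now, the only change shown was on the sulfonamide nitrogen; this step shows that the six-membered aromatic ring of the phenyl, on a saturated chain carbon bound to an amide-type nitrogen in a ring, can give way to an open chain with a triple bond without a lower number appearing. The size of this step cannot be read, because the value for compound 3 is a limit and not a number: the limit of > 50 ug/mL in this assay, at which 2 of the 3 values shown sit.

On these data alone, whether an amine or a carboxylic acid at this same place would bring a lower number stays open. So does how much compound 2 and compound 3 are tolerated beyond the limit.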